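The source may report more compounds than this note shows. Statements on the series, on what has been measured and on what is new or still open speak of the compounds shown alone.

Measured compounds:
Compound 1 `COc1cc(C(=O)/C(C#N)=C/c2ccc(OC)c(OC)c2OC)cc(OC)c1OC`: in an ADME assay on K562 cells (Homo sapiens) for cytotoxicity, read by MTT assay, with a stated time of 5 days (a lower number here means a stronger inhibitor, a higher number a weaker inhibitor), compound 1 gives > 10000 nM, a limit of the assay rather than a number.
Compound 2 `COc1ccc(/C=C(\C#N)C(=O)c2cc(OC)c(OC)c(OC)c2)cc1F`: in this assay compound 2 gives > 10000 nM, likewise a limit.
Compound 3 `CCOC(=O)/C(=C/c1ccc(OC)cc1)C(=O)c1cc(OC)c(OC)c(OC)c1`: in this assay compound 3 gives > 10000 nM, again a limit.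

Compound 3 therefore stands at the limit and nowhere else, as shown by the limit of > 10000 nM in this assay, at which 3 of the 3 values shown sit; no number exists for it, and no step between measured compounds can be drawn. Compound 4 `CCOC(=O)/C(=C/c1ccc(OC)c(O[Si](C)(C)C(C)(C)C)c1)C(=O)c1cc(OC)c(OC)c(OC)c1` is the unmeasured analogue. Its change from compound 3 is a group of 8 heavy atoms (6 carbon, 1 oxygen, 1 silicon; no ring) in place of a hydrogen atom, on an aromatic carbon, a group of 8 heavy atoms in place of a hydrogen atom, on an aromatic carbon. Going by the values given here, with compound 3 known only as a limit, no step of any size can be expected in this assay beyond the scatter. The estimate for compound 4 is 20000 nM (range 5000 nM to 100000 nM), an expected step that the limit leaves unreadable from compound 3 to compound 4 that is nominally none.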

Compound 4, half-maximal inhibitory concentration: 4290 nM
Estimate against measurement, compound 4: 4.7-fold (0.67 log units) above; the whole stated range lies above it.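

In this assay the change gives an at least 2.3-fold lower number from compound 3 to compound 4 (0.36 log units; beyond the scatter) and puts a number in place of a limit, on the aromatic carbon ortho to a methoxy group. A group of 8 heavy atoms on this carbon therefore does not abolish the read-out, and compound 4 alone among those shown gives a number. The full size of the step cannot be read: the limit of > 10000 nM in this assay, at which 3 of the 4 values shown sit.

Open, from the compounds shown here alone, is whether a hydroxyl or an amine on the same carbon also gives a number, or whether the silicon-bearing group is needed.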